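Xanthine sulfonamides: aryl versus benzyl on the ring amine

The source may hold more compounds than are shown below. What is called first, only, known or untested is meant among the compounds shown, and "the series" means these compounds.

Measured so far:
compound 1 `CCCn1c(=O)c2[nH]c(-c3ccc(S(=O)(=O)N4CCN(c5ccc(Cl)cc5)CC4)cc3)nc2n(CC)c1=O` — 4.31 nM
compound 2 `CCCn1c(=O)[nH]c2nc(-c3ccc(S(=O)(=O)N4CCN(C)CC4)cc3)[nH]c2c1=O` — 48.2 nM
compound 3 `CCCn1c(=O)[nH]c2nc(-c3ccc(S(=O)(=O)N4CCN(Cc5ccc(Br)cc5)CC4)cc3)[nH]c2c1=O` — 0.153 nM

In an assay on CHO cells for displacement of a labelled ligand from adenosine receptor A2b (Homo sapiens), read by scintillation counting, with a stated time of 75 min, in the presence of a further agent that is not named here (a higher number here means a weaker inhibitor, a lower number a stronger inhibitor), compound 3 gives the lowest number of the three, with compound 1 the nearest and compound 2 the furthest, both beyond the scatter. Going by the values given here, the one measured step that bears on the present change is a 320-fold lower number from compound 2 to compound 3 (2.50 log units; beyond the scatter), which shows how much the group on the ring amine nitrogen can move this assay. Compound 1 carries a halogenated phenyl on the same kind of nitrogen, but on a different core, so its two values with compound 3 are noted only as they stand.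

Compound 4 `CCCn1c(=O)[nH]c2nc(-c3ccc(S(=O)(=O)N4CCN(c5cccc(F)c5)CC4)cc3)[nH]c2c1=O` is the next compound, differing from compound 3 by 3-fluorophenyl in place of 4-bromobenzyl on an amine nitrogen in a ring. The group that enters is one atom shorter than the one that leaves and is again a halogenated aromatic ring. Given a 320-fold lower number from compound 2 to compound 3 (2.50 log units; beyond the scatter), the large effect of an aromatic group at this nitrogen is expected to be kept in part, though a weakening is estimated relative to compound 3, as a 20-fold higher number from compound 3 to compound 4 (1.29 log units; beyond the scatter). Compound 4 is thus expected to give 3 nM in this assay, within 0.5 nM to 20 nM.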

Compound 4, inhibition constant: 0.632 nM
Beside the measured number, compound 4's estimate is 4.7-fold (0.68 log units) above it; the range from low to high includes it.
By their numbers in this assay, from the lowest: compound 3; then compound 4; then compound 1; then compound 2.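

In this assay, a halogenated aromatic ring held directly on the amine nitrogen in a ring also gives a large gain over methyl, with a 76-fold lower number from compound 2 to compound 4 (1.88 log units; beyond the scatter), so the large step of a 320-fold lower number from compound 2 to compound 3 (2.50 log units; beyond the scatter) does not depend on 4-bromobenzyl alone. The exchange of 4-bromobenzyl for 3-fluorophenyl is modest by comparison, at a 4.1-fold higher number from compound 3 to compound 4 (0.62 log units; beyond the scatter), and both compounds remain well ahead of the methyl compound. No supporting data bear on why this exchange gives a step of this size.

From the compounds shown here alone, this step changes the carbon link, the halogen and the halogen's place together, so the share of each remains open. An unsubstituted phenyl or benzyl group could help to separate them, and a cyclohexyl ring could show whether an aromatic ring is needed on this nitrogen.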